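The source may hold more compounds than are shown below. What is called first, only, known or untested is meant among the compounds shown, and "the series" means these compounds.

Working notes on the series. Compound 1 `COc1ccnc(-c2cnc(C(=O)CCCCCCc3ccccc3)o2)c1` gives 0.8 nM in an assay (Rattus norvegicus) for inhibition of Fatty-acid amide hydrolase 1 (Homo sapiens); a higher number here means a weaker inhibitor, a lower number a stronger inhibitor. Within the data shown here, compound 2 `CC(=O)c1cnc(C(=O)CCCCCCc2ccccc2)o1` gives 2 nM in this assay, the higher of the two numbers so far; its nearest neighbour is compound 1, and the only measured step, a 2.5-fold higher number from compound 1 to compound 2 (0.40 log units; beyond the scatter), separates the pair. Compound 3 `CN1CCN(C(=O)c2cnc(C(=O)CCCCCCc3ccccc3)o2)CC1` is not yet measured. It differs from compound 2 by 4-methylpiperazin-1-yl in place of methyl on a carbonyl carbon; cut one bond further out, the change reads acetyl to (4-methylpiperazin-1-yl)carbonyl. Among the measured compounds shown here, only one measured step touches this part of the molecule: a 2.5-fold higher number from compound 1 to compound 2 (0.40 log units; beyond the scatter), a modest change when 4-methoxypyridin-2-yl gave way to acetyl. One step cannot fix a direction for a second exchange at the same carbonyl carbon, so the expected step of a 1.3-fold higher number from compound 2 to compound 3 (0.10 log units; within the scatter) is put at no change beyond the scatter. Compound 3 is therefore estimated at 2.5 nM, within a range of 0.7 nM to 9 nM.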

Compound 3, inhibition constant: 80 nM
Compound 3: middle estimate off by 32-fold (1.51 log units), on the low side; the measured number lies above the stated range.
By their numbers in this assay, from the lowest: compound 1; then compound 2; then compound 3.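

The change at this place is far larger than the earlier pair suggested: a 40-fold higher number from compound 2 to compound 3 (1.60 log units; beyond the scatter) on the carbonyl carbon, against only a 2.5-fold higher number from compound 1 to compound 2 (0.40 log units; beyond the scatter) for the first exchange. Replacing 4-methoxypyridin-2-yl on the aromatic carbon with (4-methylpiperazin-1-yl)carbonyl gives a 100-fold higher number from compound 1 to compound 3 (2.00 log units; beyond the scatter) and places the new group well apart from the other two, so this position does not accept every substituent equally in this assay. Nothing available explains the loss.

The compounds shown do not separate the contribution of the 4-methylpiperazin-1-yl ring from that of the new carbonyl attachment as a whole. On these data alone, how a morpholine amide, a smaller dimethylamino amide or a carboxylic acid on the same aromatic carbon would stand remains open.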